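Cyclopropyl to piperidin-1-yl on the amide-type nitrogen

The source may report more compounds than this note shows. Statements on the series, on what has been measured and on what is new or still open speak of the compounds shown alone.

Measured in a physicochemical assay for solubility, read by HPLC, in phosphate buffer, measured as kinetic solubility, at pH 7.4; on this read-out higher numbers stand for higher solubility and lower numbers for lower solubility:
compound 1 `NS(=O)(=O)c1ccc(-c2cc(C(=O)CC3CCCC3)nn2-c2ccc(Cl)cc2)cc1`: 2600 nM
compound 2 `NS(=O)(=O)c1ccc(-c2cc(C(=O)NC3CC3)nn2-c2ccc(Cl)cc2)cc1`: 72600 nM

Compound 2 stands highest of the two numbers. Compound 3 `NS(=O)(=O)c1ccc(-c2cc(C(=O)NN3CCCCC3)nn2-c2ccc(Cl)cc2)cc1` differs from it as follows: piperidin-1-yl in place of cyclopropyl on an amide-type nitrogen. Among the measured compounds shown here, only one measured step bears on this change, and only indirectly: a 28-fold higher number from compound 1 to compound 2 (1.45 log units; beyond the scatter), a large step, with cyclopropylamino in place of cyclopentylmethyl on a carbonyl carbon. In this assay a lower number is expected, in a step smaller than that one but probably beyond the scatter: a 3.6-fold lower number from compound 2 to compound 3 (0.56 log units; beyond the scatter). For compound 3 the estimated value is 20000 nM, with an expected range of 6000 nM to 60000 nM.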

Compound 3, solubility: 53700 nM
For compound 3 the middle estimate is 2.7-fold (0.43 log units) below the measured one; measured number inside the range.
By their numbers in this assay, from the lowest: compound 1; then compounds 3 and 2 (each within the scatter of the next).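

In this assay, the move to piperidin-1-yl on the amide-type nitrogen gives a 1.4-fold lower number from compound 2 to compound 3 (0.13 log units; within the scatter), so this position accepts a six-membered ring carrying a hetero atom with no change beyond the scatter. The large gain over the cyclopentylmethyl ketone is also not confined to cyclopropylamino, with a 21-fold higher number from compound 1 to compound 3 (1.32 log units; beyond the scatter) for (piperidin-1-yl)amino in its place. No supporting data bear on the reason for this result.

Open, as far as these compounds go, is how a morpholine ring or a longer alkyl chain on this nitrogen would read. Also open, from the compounds shown here alone, is how an unsubstituted amide would compare.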